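Amide aryl series: from phenyl to 3-chloro-4-methylphenyl

The source may hold more compounds than are shown below. What is called first, only, known or untested is meant among the compounds shown, and "the series" means these compounds.

Compound 1 `Cc1cccc2sc(NC(=O)COc3ccc(/C=C4\SC(=O)NC4=O)cc3)nc12` and compound 2 `O=C(COc1ccc(/C=C2\SC(=O)NC2=O)cc1)Nc1ccccc1` share a core on which an amide nitrogen carries an aryl group. In a functional assay on KB cells (Homo sapiens) for inhibition (a lower number here means a stronger inhibitor of growth, a higher number a weaker inhibitor of growth), compound 1 returns no number but only the limit of the assay, > 100000 nM. In this assay compound 2 likewise gives only a limit, > 100000 nM. Compound 2 therefore stands not at a measured number but at the ceiling of what this assay reports, where both values at hand sit together (the limit of > 100000 nM in this assay, at which 2 of the 2 values shown sit). Among the measured compounds shown here, no step between measured compounds is available for this series. Compound 3 `Cc1ccc(NC(=O)COc2ccc(/C=C3\SC(=O)NC3=O)cc2)cc1Cl` differs from compound 2 by 3-chloro-4-methylphenyl in place of phenyl on an amide-type nitrogen. Because both measured values rest at the ceiling (the limit of > 100000 nM in this assay, at which 2 of the 2 values shown sit), the step expected in this assay is a number no higher from compound 2 to compound 3 (the limit leaves the size open), none beyond the scatter, and the most likely outcome is a further limit. Compound 3 is estimated at 100000 nM, with a range from 30000 nM to 300000 nM.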

Compound 3, concentration for 50% growth inhibition: 99600 nM
Estimate against measurement, compound 3: 1.0-fold (0.00 log units) above, within the range that was stated.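

Among the compounds shown here, compound 3 gives 99600 nM in this assay, the first value in this set that is a number and not a limit. It shows that 3-chloro-4-methylphenyl on the amide-type nitrogen can bring a member of the series within the reported range, although the step reads only as a number no higher from compound 2 to compound 3 (the limit leaves the size open) and its size cannot be read. The series otherwise remains at the ceiling: the limit of > 100000 nM in this assay, at which 2 of the 3 values shown sit.

The compounds shown leave open whether the chlorine alone or the methyl alone would yield a number in this assay. They also leave open whether an aryl group carrying an amine or a carboxylic acid, or a longer chain on the amide-type nitrogen, would give a value clearly lower than that of compound 3.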